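The source may report more compounds than this note shows. Statements on the series, on what has been measured and on what is new or still open speak of the compounds shown alone.

Compound 1 `FC(F)(F)Oc1ccc(Nc2ncnc3c2cnn3C2CCCCC2)cc1` was tested in an ADME assay on BaF3 cells (Mus musculus) for cytotoxicity (a higher number here means that more compound is needed for the effect, a lower number that less compound is needed), and gave 9300 nM. Among the values shown for this series, compound 1 carries the only number; the other two results stand at a limit rather than as numbers. Compound 2 `O=C(NCCO)c1cc2c(Nc3ccc(OC(F)(F)F)cc3)ncnc2s1` reached only the limit of > 10000 nM in this assay. Compound 3 `OCCn1cc2c(Nc3ccc(OC(F)(F)F)cc3)ncnc2n1` likewise reached only the limit of > 10000 nM in this assay. Going by the values given here, compound 1 is therefore the one compound with a half-maximal effective concentration actually read, and that reading sits near (the limit of > 10000 nM in this assay, at which 2 of the 3 values shown sit).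

Compound 4 `FC(F)(F)Oc1ccc(Nc2ncnc3c2cnn3CC2CCOC2)cc1` has not yet been measured. It differs from compound 1 in a single place: (oxolan-3-yl)methyl in place of cyclohexyl on an aromatic nitrogen. Among the compounds with values here, no step between two measured compounds is known in this set, so there is no measured change of this kind to lean on. Because compound 1 gives 9300 nM, a value near (the limit of > 10000 nM in this assay, at which 2 of the 3 values shown sit), compound 4 is expected to land at much the same level, with an expected step of a 1.1-fold higher number from compound 1 to compound 4 (0.03 log units; within the scatter) that does not go beyond the scatter. Compound 4 is thus estimated at 10000 nM, between 5000 nM and 20000 nM, and it may well be reported only as a limit.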

Compound 4, half-maximal effective concentration: > 10000 nM
Compound 4 gave a limit, no number; the forecaster's own chance of this, stated with the estimate: 50%; the middle value lies on the limit itself.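

Going by these compounds alone, the change of cyclohexyl to (oxolan-3-yl)methyl on an aromatic nitrogen, next to the ring nitrogen, gives the only step between measured compounds in this set, and in this assay it reads as an at least 1.0-fold higher number from compound 1 to compound 4 (0.03 log units; that floor lies within the scatter). Compound 4 stands at a limit, > 10000 nM, and not at a number, so this position takes a ring with an oxygen and a hydrogen-bond acceptor in place of a ring of carbon only without any lower number appearing. The true size of the step cannot be read beyond that floor, and the compounds now gather at one reading: the limit of > 10000 nM in this assay, at which 3 of the 4 values shown sit.

Compound 1 therefore remains the only compound with a number, and nothing shown tells how far the other compounds lie from it or whether any substituent on this nitrogen would give a clearly lower number. Going by these compounds, the effect of an amine, a carboxylic acid or a longer carbon chain at this position remains open, as does that of a change elsewhere on the shared core.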